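Trading phenyl for thiophen-3-yl in compound 1

This account rests on a few compounds, and the source may have more. Where it says the series, first, only, none or still open, it means among the compounds named here.

Within the data shown here, in a functional assay on the whole organism with Mus musculus as the target (a lower number here means that less compound is needed, a higher number that more compound is needed for the effect), compound 1 `C[C@@H](NCc1ccc(OCc2ccccc2)cc1)C(N)=O` gives 23.8 mg/kg, the second highest of three numbers so far. Compound 2 `CNC(=O)[C@H](C)NCc1ccc(OCc2ccccc2)cc1` gives 8.4 mg/kg and compound 3 `CNC(=O)[C@@H](NCc1ccc(OCc2ccccc2)cc1)C(C)C` gives 55.4 mg/kg, which places compound 1 between the other two.

Compound 4 `C[C@@H](NCc1ccc(OCc2ccsc2)cc1)C(N)=O` keeps the rest of compound 1 but has thiophen-3-yl in place of phenyl on a saturated chain carbon bound to an oxygen on an aromatic ring.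

The measured steps all alter the group on the amine nitrogen instead. They are a 2.8-fold lower number from compound 1 to compound 2 (0.45 log units; beyond the scatter), a 2.3-fold higher number from compound 1 to compound 3 (0.37 log units; beyond the scatter) and a 6.6-fold higher number from compound 2 to compound 3 (0.82 log units; beyond the scatter). None of them touches the phenyl, so they only show how far numbers have moved in this small series. Among the measured compounds shown here, no measured example of this ring exchange exists, so no step beyond the scatter is expected in this assay, and no direction is favoured. The expected step is a 1.1-fold lower number from compound 1 to compound 4 (0.03 log units; within the scatter) as the estimate stands. For compound 4 the estimated dose is 22 mg/kg, with an expected range from 10 mg/kg to 50 mg/kg.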

Compound 4, dose for half-maximal effect: 114 mg/kg
Compound 4: middle estimate off by 5.2-fold (0.71 log units), on the low side, outside the stated range (above it).
By their numbers in this assay, from the lowest: compound 2; then compound 1; then compound 3; then compound 4.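

Among these compounds, the change on a saturated chain carbon bound to an oxygen on an aromatic ring is the first one here made away from the amine nitrogen, and in this assay it gives a 4.8-fold higher number from compound 1 to compound 4 (0.68 log units; beyond the scatter) in the direction of needing more compound. This shows that the position is not indifferent to the ring it carries: thiophen-3-yl, a five-membered aromatic ring holding sulfur, does not simply stand in for phenyl in the whole mouse. Nothing available here accounts for this loss.

On these data alone, it remains open whether the same exchange would cost as much on the group carried by compound 2 or compound 3. Also open, as far as these compounds go, is how other rings at this position would fare, such as thiophen-2-yl, furan-3-yl or a pyridine ring.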